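N-methylation of the ring amine in compound 1

The source may report more compounds than this note shows. Statements on the series, on what has been measured and on what is new or still open speak of the compounds shown alone.

Measured in a functional assay on WM164 cells (Homo sapiens) for antiproliferative activity, read by sulforhodamine B assay, with a stated time of 48 h; on this read-out lower numbers stand for stronger inhibition and higher numbers for weaker inhibition:
- compound 1 `CCCCCCCCCCCCCCCCNC(=O)[C@@H]1CSC(c2ccc(NC(C)=O)cc2)N1`: 600 nM
- compound 2 `CCCCCCCCCCCCCCCCNC(=O)[C@@H]1CSC(c2ccc(N)cc2)N1`: 1400 nM

Not yet measured: compound 3 `CCCCCCCCCCCCCCCCNC(=O)[C@@H]1CSC(c2ccc(NC(C)=O)cc2)N1C`.

In this assay compound 1 holds the lower of the two numbers, at 600 nM. Compound 3 carries methyl in place of hydrogen on an amine nitrogen in a ring, with the rest of compound 1 unchanged: methyl in place of hydrogen on an amine nitrogen in a ring.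

For the measured compounds named here, only one measured step exists, a 2.3-fold higher number from compound 1 to compound 2 (0.37 log units; beyond the scatter). It is modest, though beyond the scatter. It replaces acetyl with hydrogen on a nitrogen on an aromatic ring, so it sits at a different place and does not test the ring amine. Going by the values given here, no measured compound carries a substituent on that amine, so the direction of the new step remains open. The size of the compound 2 step, a 2.3-fold higher number from compound 1 to compound 2 (0.37 log units; beyond the scatter), serves only as a rough guide to how far one small change can move this series. A step of similar modest size is expected, leaning towards a higher number, with no change beyond the scatter also possible.

The estimate is a 1.7-fold higher number from compound 1 to compound 3 (0.22 log units; within the scatter), an expected small loss. Compound 3 is expected at about 1000 nM, with an estimated range of 350 nM to 3000 nM.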

Compound 3, half-maximal inhibitory concentration: > 100000 nM
Compound 3 ended at the assay's limit (the forecaster's own chance of this, stated with the estimate: 3%); middle value at least 100-fold (2.00 log units) from the limit.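

In this assay compound 3 gives > 100000 nM, which is a limit of the assay and not a number: the limit of > 100000 nM in this assay, at which 1 of the 3 values shown sits.

Methyl in place of hydrogen on the amine nitrogen in the ring gives an at least 160-fold higher number from compound 1 to compound 3 (2.22 log units; beyond the scatter), a large step, whereas the only earlier step, at the nitrogen on the aromatic ring, was modest at a 2.3-fold higher number from compound 1 to compound 2 (0.37 log units; beyond the scatter). This shows that the ring amine is far less tolerant of this small change than the earlier pair could reveal, and that the series can lose measurable activity in this assay through the gain of a single methyl, with the rest of compound 1 unchanged.

The compounds shown leave open whether the loss belongs to methyl in particular or to any substituent on that nitrogen, a question that an ethyl or a formyl group there would address. They also leave open whether the same methyl would cost as much with the free amine of compound 2 on the aromatic ring, or with a shorter chain on the amide nitrogen in place of the long chain.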